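Swapping the allyl(methyl)amino group of compound 2 for an anilide

The compounds below may be only part of what the source reports. "The series", "measured", "known", "first", "only" and "open" are said of these compounds alone.

In a functional assay on MCF7 cells (Homo sapiens) for antiproliferative activity, read by MTT assay, with a stated time of 48 h (on this read-out lower numbers stand for stronger inhibition and higher numbers for weaker inhibition), compound 1 (`CCN(CC)CCNC(=O)c1ccc(C(CC)(CC)c2ccc(OCCC(O)(CC)CC)c(C)c2)n1CC`) gives 550 nM as a measured number. Compound 2 (`C=CCN(C)C(=O)c1ccc(C(CC)(CC)c2ccc(OCCC(O)(CC)CC)c(C)c2)n1CC`) gives > 50000 nM there, which is a limit of the assay and not a number. Compound 2 therefore has no exact place on the scale, and the evidence on it is the limit of > 50000 nM in this assay, at which 1 of the 2 values shown sits, and nothing firmer.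

In compound 3 (`CCn1c(C(=O)Nc2cccc(C(F)(F)F)c2)ccc1C(CC)(CC)c1ccc(OCCC(O)(CC)CC)c(C)c1`) the change from compound 2 is (3-(trifluoromethyl)phenyl)amino in place of allyl(methyl)amino on a carbonyl carbon and the words for it are simple: (3-(trifluoromethyl)phenyl)amino in place of allyl(methyl)amino on a carbonyl carbon.

Among the compounds with values here, only one measured step bears on this change. It is an at least 90-fold higher number from compound 1 to compound 2 (1.95 log units; beyond the scatter) and it is large, with allyl(methyl)amino in place of (2-(diethylamino)ethyl)amino at the same carbonyl carbon. Compound 3 does not regain the group of compound 1, which gives 550 nM, so a full return to that level is not expected.

A moderate move to a lower number is expected in this assay, and the estimated step is an at least 3.3-fold lower number from compound 2 to compound 3 (0.52 log units; beyond the scatter), though another limit remains possible. For compound 3 the estimated value is 15000 nM, with an expected range from 3000 nM to 50000 nM.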

Compound 3, half-maximal inhibitory concentration: > 50000 nM
Compound 3 ended at the assay's limit; the forecaster's own chance of this, stated with the estimate: 40%; at least 3.3-fold (0.52 log units) between middle value and limit.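

In this assay compound 3 shows that the loss seen with compound 2 is not confined to allyl(methyl)amino: a very different group on the same carbonyl carbon, carrying an aromatic ring and the amide hydrogen, also ends at a limit of the assay and not at a number: the limit of > 50000 nM in this assay, at which 2 of the 3 values shown sit.

Set against the only measured value, the result is an at least 90-fold higher number from compound 1 to compound 3 (1.95 log units; beyond the scatter), so the amide hydrogen, which the (2-(diethylamino)ethyl)amino group of compound 1 also carries, does not by itself bring back a measured value. The step between compound 2 and compound 3 cannot be read, as both values are limits, and neither compound can be ranked against the other.

Going by these compounds, what remains open is which part of the (2-(diethylamino)ethyl)amino group goes with the measured value of compound 1, the diethylamino nitrogen or the ethyl chain that carries it. A (3-(diethylamino)propyl)amino group with its longer chain, or a (2-hydroxyethyl)amino group with no amine in it, would separate these two parts on the same carbonyl carbon.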